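Isopropoxy carbonate swap on the branched linker

This account rests on a few compounds, and the source may have more. Where it says the series, first, only, none or still open, it means among the compounds named here.

Values in an ADME assay on a cell-free system (plasma, Mus musculus, strain CD-1) for metabolic stability, read by LC-MS, with a stated time of 2 h, tested at 1 ug/mL; on this read-out higher numbers stand for a more stable compound and lower numbers for a less stable compound:
- compound 1 `CC(C)OC(=O)OCOC(=O)c1ccc(N)cc1O`: 0%
- compound 2 `CC(C)(C)C(=O)OCOC(=O)c1ccc(N)cc1O`: 0%
- compound 3 `CC(OC(=O)c1ccc(N)cc1O)OC(=O)C(C)(C)C`: 0%
- compound 4 `CC(C)OC(=O)OC(C)OC(=O)c1ccc(N)cc1O`: not yet measured

In this assay compound 3 gives 0%, level with the other two measured compounds. The change to compound 4 is isopropoxy in place of tert-butyl on a carbonyl carbon. The reverse swap gave no change at the digits printed from compound 1 to compound 2 (within the scatter). The added methyl gave no change at the digits printed from compound 2 to compound 3 (within the scatter). Neither step shows any movement, so no shift beyond the scatter is expected, and the estimated step is no change at the digits printed from compound 3 to compound 4 (within the scatter). For compound 4 the estimate is 0%, with an expected range of 0% to 5%.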

Compound 4, percent of the compound remaining: 0%
Compound 4: middle estimate and measured number agree at the digits printed; low and high end bracket the measured number.
By their numbers in this assay, from the lowest: compounds 1, 2, 3 and 4 (each within the scatter of the next).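

In this assay, isopropoxy in place of tert-butyl on a carbonyl carbon gives no change at the digits printed from compound 3 to compound 4 (within the scatter), and methyl in place of hydrogen on the saturated chain carbon bound to two oxygens gives no change at the digits printed from compound 1 to compound 4 (within the scatter). The swap on the carbonyl carbon now reads the same on two cores: the same change on two cores in this assay, no change at the digits printed (within the scatter) from compound 1 to compound 2 and no change at the digits printed (within the scatter) from compound 4 to compound 3, 0 percentage points apart, within the scatter of two such steps The methyl also reads the same on two cores: the same change on two cores in this assay, no change at the digits printed (within the scatter) from compound 2 to compound 3 and no change at the digits printed (within the scatter) from compound 1 to compound 4, 0 percentage points apart, within the scatter of two such steps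

With all four compounds at one printed value, this read-out does not separate these changes. Going by these compounds, what an amine or a longer chain in place of isopropoxy would give on this carbonyl carbon remains open.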